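Swapping one para hydrogen for fluorine on a trimethoxyphenyl urea

The source may hold more compounds than are shown below. What is called first, only, known or untested is meant among the compounds shown, and "the series" means these compounds.

The shared core carries two methylated urea nitrogens linking a trimethoxyphenyl group to a second aromatic ring. Compound 1 `COc1cc(N(C)C(=O)N(C)c2ccc([N+](=O)[O-])cc2)cc(OC)c1OC` bears a nitro group on that ring; in a functional assay on ONS-76 cells (Homo sapiens) for cytotoxicity, read by MTT assay, with a stated time of 72 h (a lower number here means a stronger inhibitor, a higher number a weaker inhibitor), compound 1 reaches only a limit of the assay, >= 125000 nM. Compound 2 `COc1cc(N(C)C(=O)N(C)c2ccccc2)cc(OC)c1OC` has an unsubstituted ring, and in this assay compound 2 stands at "not determined" (no result reported), so it anchors no number. Compound 3 `COc1cc(N(C)C(=O)N(C)c2ccc(F)cc2)cc(OC)c1OC` differs from compound 2 by fluoro in place of hydrogen on an aromatic carbon. With no measured step shown, the expected change in this assay is none beyond the scatter. Compound 3 is estimated at 100000 nM, within 20000 nM to 300000 nM.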

Compound 3, half-maximal inhibitory concentration: >= 125000 nM
Compound 3: only a limit was reported; the forecaster's own chance of this, stated with the estimate: 60%; middle value at least 1.2-fold (0.09 log units) away from the limit.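

No step can be read from compound 1 to compound 3, because both results are the same limit of the assay and not numbers: the limit of >= 125000 nM in this assay, at which 2 of the 3 values shown sit.

In this assay the compounds shown leave open whether any group on that second aromatic ring gives a measurable number.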